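The compounds below may be only part of what the source reports. "The series", "measured", "known", "first", "only" and "open" are said of these compounds alone.

Measured compounds in an ADME assay on MDBK cells (Bos taurus) for cytotoxicity, read by MTT assay; a lower number here means that less compound is tolerated, a higher number that more compound is tolerated:
- compound 1, `CCCC1CCCCC1OCCCCCCN1C[C@H](O)[C@@H](O)[C@H](O)[C@H]1CO`: 150000 nM
- compound 2, `OC[C@@H]1[C@@H](O)[C@H](O)[C@@H](O)CN1CC/C=C/CCOc1cc(F)ccc1F`: > 500000 nM, which is a limit of this assay and not a number
- compound 3, `Cc1ccc(C(C)C)c(OCCCCCCN2C[C@H](O)[C@@H](O)[C@H](O)[C@H]2CO)c1`: 62000 nM

All three share the same polyhydroxylated piperidine core with a hydroxymethyl group, joined through a linker to an ether-bound aryl or cycloalkyl group. Among the two numbers in hand, compound 1 has the higher one; compound 3 sits at a lower number, and that gap lies beyond the usual scatter of repeat measurements. Compound 2 gives only a limit, as noted in the limit of > 500000 nM in this assay, at which 1 of the 3 values shown sits.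

The next compound is compound 4, `COc1ccccc1OCCCCCCN1C[C@H](O)[C@@H](O)[C@H](O)[C@H]1CO`. It differs from compound 1 in one place:
a group of 8 heavy atoms (7 carbon, 1 oxygen; one six-membered aromatic ring of carbon only) in place of a group of 9 heavy atoms (9 carbon; one six-membered non-aromatic ring of carbon only), on an oxygen on a saturated carbon

Among the compounds with values here, no directly measured pair differs by this change, so the size of the step is an expectation only. Compound 2 , the other aromatic ether in the set, reaches only the limit, while compound 3 , also aromatic, gives the lowest number; the expectation therefore takes a middle course. For compound 4 the expected value is 250000 nM, within 100000 nM to 600000 nM. This estimate implies a step of a 1.7-fold higher number from compound 1 to compound 4 (0.22 log units; within the scatter), expected to be modest and towards a higher number, with a real chance that only a limit is reported.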

Compound 4, half-maximal cytotoxic concentration: > 500000 nM
Compound 4 ended at the assay's limit; the forecaster's own chance of this, stated with the estimate: 30%; at least 2.0-fold (0.30 log units) between middle value and limit.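

Placed on the oxygen on a saturated carbon, 2-methoxyphenyl in place of the group of 9 heavy atoms with its six-membered non-aromatic ring gives an at least 3.3-fold higher number from compound 1 to compound 4 (0.52 log units; beyond the scatter) in this assay, the first readable step in the series and one that lies beyond the scatter. Compound 3 also carries a six-membered aromatic ring at this place and gives 62000 nM, so an aromatic ring at this position does not by itself bring a compound to the top of the range. Compound 4 gives > 500000 nM, which is a limit of the assay and not a number, and it shares that limit with one other compound: the limit of > 500000 nM in this assay, at which 2 of the 4 values shown sit.

The size of the step therefore has only a lower bound, and the compounds shown do not separate the contribution of the methoxy group from that of the aromatic ring. A plain phenyl group or a 2-aminophenyl group in the same place would make that separation, and a longer chain would test whether the result holds beyond this linker.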